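Methyl to amino: the step to compound 4

A few compounds are considered here, and "the series" means these few. Any claim that something is new, unique, unknown or untested is made for them only; others in the source may bear on it.

In a functional assay on SJSA-1 cells (Homo sapiens) for antiproliferative activity, read by fluorescence, with a stated time of 72 h (a lower number here means a stronger inhibitor, a higher number a weaker inhibitor), compound 1 (`Cc1nnc(-c2nc(C3CCCCC3)n(-c3cccc(Cl)c3F)c2-c2ccc(F)c(Cl)c2)o1`) gives 5900 nM as the lowest of three numbers. Compound 2 (`O=C(O)c1nc(-c2ccccc2)n(-c2cccc(Cl)c2F)c1-c1ccc(F)c(Cl)c1`) gives 14000 nM and compound 3 (`Cc1ccc(Cl)cc1-n1c(-c2ccccc2)nc(C(=O)O)c1-c1cccc(Cl)c1`) gives 16100 nM, and each of these lies beyond the scatter from compound 1. Compound 4 (`Nc1nnc(-c2nc(C3CCCCC3)n(-c3cccc(Cl)c3F)c2-c2ccc(F)c(Cl)c2)o1`) keeps the core of compound 1 but has amino in place of methyl on an aromatic carbon. That turns 5-methyl-1,3,4-oxadiazol-2-yl into 5-amino-1,3,4-oxadiazol-2-yl. For the measured compounds named here, no measured pair shows this change, so the expectation is uncertain: no step beyond the scatter, with a slight lean towards a lower number. The estimated step runs (a 1.3-fold lower number from compound 1 to compound 4 (0.12 log units; within the scatter)) on that reading. In this assay compound 4 is expected at (4500 nM), within an estimated range from (1500 nM) to (14000 nM).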

Compound 4, half-maximal inhibitory concentration: 3500 nM
For compound 4 the middle estimate is 1.3-fold (0.11 log units) above the measured one, within the range that was stated.
By their numbers in this assay, from the lowest: compounds 4 and 1 (each within the scatter of the next); then compounds 2 and 3 (each within the scatter of the next).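

For the compounds shown here, the step of a 1.7-fold lower number from compound 1 to compound 4 (0.23 log units; within the scatter) gives the first measured pair in this assay that differs in one place. It shows that this position takes amino as well as methyl, adding a hydrogen-bond donor and a hydrogen-bond acceptor without a step beyond the scatter. Nothing available accounts for how close the two compounds stand.

From the compounds shown here alone, whether a larger group here, such as ethyl or dimethylamino, would also stay within the scatter of compound 1 remains open.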